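Pyridinylaminomethyl in Place of Benzylamino on the Piperidine Carbon

The compounds below may be only part of what the source reports. "The series", "measured", "known", "first", "only" and "open" are said of these compounds alone.

Of the compounds shown here, two sharing one core have been measured in an assay on CHO cells for displacement of a labelled ligand from 5-hydroxytryptamine receptor 1D (Homo sapiens); a lower number here means a stronger inhibitor, a higher number a weaker inhibitor. Compound 1 `CC(C)=CCCN(C)C1CCN(CCCc2c[nH]c3ccc(-n4cnnc4)cc23)CC1` gives 2.6 nM. Compound 2 `c1ccc(CNC2CCN(CCCc3c[nH]c4ccc(-n5cnnc5)cc34)CC2)cc1` gives 4.6 nM. The step of a 1.8-fold higher number from compound 1 to compound 2 (0.25 log units; within the scatter) exchanges one amine on the saturated ring carbon for another, and the numbers of compound 2 and compound 1 cannot be told apart by this measurement; compound 2 stands at the higher of the two numbers, but within the scatter of compound 1.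

Compound 3 `c1ccc(NCC2CCN(CCCc3c[nH]c4ccc(-n5cnnc5)cc34)CC2)nc1` differs from compound 2 by ((pyridin-2-yl)amino)methyl in place of benzylamino on a saturated ring carbon. Going by the values given here, no measured step bears on this particular exchange; the only step available, from compound 1 to compound 2, shows that a large change at this same ring carbon left the number within the scatter. On that basis, the expectation is a step of a 1.5-fold higher number from compound 2 to compound 3 (0.18 log units; within the scatter) for compound 3, with no confident direction beyond the scatter. Compound 3 is therefore estimated at 7 nM in this assay, with a range from 2 nM to 25 nM.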

Compound 3, half-maximal inhibitory concentration: 1.7 nM
Beside the measured number, compound 3's estimate is 4.1-fold (0.61 log units) above it, and the stated range ends above it.
By their numbers in this assay, from the lowest: compounds 3, 1 and 2 (each within the scatter of the next, the first and the last beyond it).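

In this assay, the exchange of benzylamino for ((pyridin-2-yl)amino)methyl gives a 2.7-fold lower number from compound 2 to compound 3 (0.43 log units; beyond the scatter) and so shows that this saturated ring carbon can register a difference between two groups of equal heavy-atom count, which the earlier pair of compounds could not show. The step is modest, and the other new step, a 1.5-fold lower number from compound 1 to compound 3 (0.18 log units; within the scatter), leaves compound 3 and compound 1 indistinguishable, so a group holding a six-membered aromatic ring with 1 hetero atom and the open-chain methyl(4-methylpent-3-en-1-yl)amino group give numbers that this measurement cannot separate. Nothing measured here accounts for the difference between compound 2 and compound 3.

The exchange alters two things at once, since the aromatic ring gains a nitrogen and the group also changes the atom through which it joins the ring carbon, so the compounds shown cannot say which of these matters. A phenylaminomethyl group, which keeps the new connection with the carbon-only ring, would separate the two, and a pyridin-3-yl in place of pyridin-2-yl would test whether the place of the ring nitrogen counts.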